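The source may hold more compounds than are shown below. What is called first, only, known or untested is meant among the compounds shown, and "the series" means these compounds.

Measured in a functional assay on HT-29 cells (Homo sapiens) for cytotoxicity, read by MTT assay, with a stated time of 24 h; on this read-out higher numbers stand for weaker inhibition and lower numbers for stronger inhibition:
compound 1 `Cn1c(-c2ccc(NC(=O)CSc3nc4cc(Cl)ccc4o3)cc2)nc(-c2ccccc2)c1-c1ccccc1` — 20.6 ug/mL
compound 2 `Cn1c(-c2ccc(NC(=O)CSc3nc4ccccc4s3)cc2)nc(-c2ccccc2)c1-c1ccccc1` — 18 ug/mL
compound 3 `Cn1cnnc1SCC(=O)Nc1ccc(-c2nc(-c3ccccc3)c(-c3ccccc3)n2C)cc1` — 10.7 ug/mL

Compound 3 carries the lowest of the three numbers, but none of the steps towards it leaves the scatter: a 1.9-fold lower number from compound 1 to compound 3 (0.28 log units; within the scatter) and a 1.7-fold lower number from compound 2 to compound 3 (0.23 log units; within the scatter), and between the other two a 1.1-fold lower number from compound 1 to compound 2 (0.06 log units; within the scatter). On these data the three compounds are not separated.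

Compound 4 `Cc1nnc(SCC(=O)Nc2ccc(-c3nc(-c4ccccc4)c(-c4ccccc4)n3C)cc2)s1` is not yet measured. Its difference from compound 3 is 5-methyl-1,3,4-thiadiazol-2-yl in place of 4-methyl-4H-1,2,4-triazol-3-yl on a sulfur. All three measured steps swap the group on that same sulfur, and none of them, not even the exchange of a fused bicyclic group for a small five-membered ring, moved the read-out beyond the scatter. The present swap exchanges one five-membered aromatic ring with three hetero atoms for another, with the same count of hydrogen-bond acceptors. The step of a 1.0-fold higher number from compound 3 to compound 4 (0.01 log units; within the scatter) is therefore expected to stay within the scatter, with no direction favoured. Compound 4 is estimated at 11 ug/mL, in the range 5 ug/mL to 25 ug/mL.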

Compound 4, half-maximal inhibitory concentration: 2.7 ug/mL
Estimate against measurement, compound 4: 4.1-fold (0.61 log units) above; measured number outside the range, below it.
By their numbers in this assay, from the lowest: compound 4; then compounds 3, 2 and 1 (each within the scatter of the next).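

Swapping the group on this sulfur can move the read-out after all: in this assay, the change gives a 4.0-fold lower number from compound 3 to compound 4 (0.60 log units; beyond the scatter), although the earlier steps at this place stayed within the scatter. The same group also separates compound 4 from both compounds with fused bicyclic groups, with a 6.7-fold lower number from compound 2 to compound 4 (0.82 log units; beyond the scatter) and a 7.6-fold lower number from compound 1 to compound 4 (0.88 log units; beyond the scatter), so compound 4 stands apart from the three earlier compounds, which could not be separated from one another. The two five-membered rings match in heavy atoms, hydrogen-bond donors and hydrogen-bond acceptors, differing in that the entering ring holds a sulfur and one nitrogen fewer, and nothing available explains the step.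

The compounds shown do not separate the contribution of the ring sulfur from that of the methyl group. Going by these compounds, it remains open how an amine or an ethyl group in place of that methyl would read.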